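Halogen swap on the anilino nitrogen: cytotoxicity notes

The compounds below may be only part of what the source reports. "The series", "measured", "known", "first", "only" and "open" are said of these compounds alone.

Compound 1 `Cc1ccc(S(=O)(=O)Cc2nc(Nc3ccc(F)cc3)c3ccccc3n2)cc1` and compound 2 `Cc1ccc(S(=O)(=O)Cc2nc(Nc3cccc(Br)c3)c3ccccc3n2)cc1` share one core; compound 3 `CC(C)=Cc1nc(Nc2ccc(F)cc2)c2cc([N+](=O)[O-])ccc2n1` and compound 4 `CC(C)=Cc1nc(Nc2cccc(Br)c2)c2cc([N+](=O)[O-])ccc2n1` share another, and the difference between the two cores is not broken down here. In an ADME assay on HepG2 cells (Homo sapiens) for cytotoxicity, read by MTT assay, with a stated time of 72 h (on this read-out higher numbers stand for weaker inhibition and lower numbers for stronger inhibition), compound 1 gives > 15000 nM, which is a limit of the assay rather than a number. Compound 2 likewise gives only a limit in this assay, namely > 15000 nM. Among the compounds with values here, compound 3 is the one compound with a number in this assay, at 27000 nM. The change from compound 1 to compound 2 is 3-bromophenyl in place of 4-fluorophenyl on a nitrogen on an aromatic ring; its step, a step that the two limits leave unreadable from compound 1 to compound 2, cannot be read because both values sit at the limit of > 15000 nM in this assay, at which 2 of the 3 values shown sit. The same change is made from compound 3 to compound 4, namely (3-bromophenyl in place of 4-fluorophenyl on a nitrogen on an aromatic ring), with the place described in the same words for both pairs. With the measured step unreadable, nothing measured says which way this change moves cytotoxicity. The step from compound 3 to compound 4 is therefore expected to be small, no change at the digits printed from compound 3 to compound 4 (within the scatter), resting on compound 3 at 27000 nM as the only anchor. Compound 4 is estimated at 27000 nM, with an expected range from 12000 nM to 60000 nM.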

Compound 4, half-maximal inhibitory concentration: > 15000 nM
Compound 4: only a limit was reported; the forecaster's own chance of this, stated with the estimate: 30%; the middle value is on the limit's open side.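

Compound 4 gives > 15000 nM in this assay, which is a limit of the assay and not a number, so no new step can be read between compound 3 and compound 4. The compounds shown leave open which way, and how far, 3-bromophenyl in place of 4-fluorophenyl on a nitrogen on an aromatic ring moves cytotoxicity on either core: the limit of > 15000 nM in this assay, at which 3 of the 4 values shown sit.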